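The source may report more compounds than this note shows. Statements on the series, on what has been measured and on what is new or still open speak of the compounds shown alone.

Measured compounds in an assay on HEK293 cells for displacement of a labelled ligand from 5-hydroxytryptamine receptor 6 (Homo sapiens), read by scintillation counting, with a stated time of 1 h; on this read-out lower numbers stand for stronger inhibition and higher numbers for weaker inhibition:

- compound 1, `C[C@H](NCc1ccc(OCCCCCN2CCN(c3cccc4c3ccn4Cc3cccc(Cl)c3)CC2)cc1)C(N)=O`, gives 232 nM
- compound 2, `C[C@H](NCc1ccc(OCCCCCN2CCN(c3cccc4c3ccn4S(=O)(=O)c3ccccc3)CC2)cc1)C(N)=O`, gives 65 nM
- compound 3, `C#CCN(C)Cc1ccc(OCCCCCN2CCN(c3cccc4c3ccn4Cc3cccc(Cl)c3)CC2)cc1`, gives 140 nM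

Compound 3 stands second highest of the three numbers. Its nearest neighbour is compound 1; the step of a 1.7-fold lower number from compound 1 to compound 3 (0.22 log units; within the scatter) lies within the scatter, so no order between the two can be claimed. Compound 2 stands furthest from compound 3, and the two values show compound 2 with the lower number.

Compound 4, `C#CCN(C)Cc1ccc(OCCCCCN2CCN(c3cccc4c3ccn4S(=O)(=O)c3ccccc3)CC2)cc1`, differs from compound 3 in one place: phenylsulfonyl in place of 3-chlorobenzyl on an aromatic nitrogen. The same exchange has been measured once in this set, from compound 1 to compound 2: a 3.6-fold lower number from compound 1 to compound 2 (0.55 log units; beyond the scatter). For the measured compounds named here, that is the only step that bears directly on the change, and it points to a lower number in this assay by a modest but real margin. The step from compound 1 to compound 3 does not concern this change.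

On that basis compound 4 is expected to give 40 nM, with a range of 15 nM to 100 nM. The expected step is a 3.5-fold lower number from compound 3 to compound 4 (0.54 log units; beyond the scatter), resting on compound 1 to compound 2 alone.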

Compound 4, inhibition constant: 38 nM
Compound 4: middle estimate off by 1.1-fold (0.02 log units), on the high side, and the stated range covers the measured number.
By their numbers in this assay, from the lowest: compounds 4 and 2 (each within the scatter of the next); then compounds 3 and 1 (each within the scatter of the next).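

In this assay the exchange of 3-chlorobenzyl for phenylsulfonyl on the aromatic nitrogen gives a 3.7-fold lower number from compound 3 to compound 4 (0.57 log units; beyond the scatter) and so no longer rests on a single pair: the same change on two cores in this assay, a 3.6-fold lower number (0.55 log units; beyond the scatter) from compound 1 to compound 2 and a 3.7-fold lower number (0.57 log units; beyond the scatter) from compound 3 to compound 4, 1.0-fold (0.01 log units) apart, within the scatter of two such steps

The exchange of (1-carbamoylethyl)amino for methyl(propargyl)amino gives a 1.7-fold lower number from compound 2 to compound 4 (0.23 log units; within the scatter) and so allows no order on the phenylsulfonyl core, as on the 3-chlorobenzyl core: the same change on two cores in this assay, a 1.7-fold lower number (0.22 log units; within the scatter) from compound 1 to compound 3 and a 1.7-fold lower number (0.23 log units; within the scatter) from compound 2 to compound 4, 1.0-fold (0.01 log units) apart, within the scatter of two such steps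

Across these four compounds, the step at the aromatic nitrogen is the same with either amino group, and no compound goes against this.

Both groups on this nitrogen carry a six-membered aromatic ring of carbon only, and they differ in both the link and the chlorine, so neither part can be credited with the step. A 3-chlorophenylsulfonyl or a methanesulfonyl group on the same nitrogen would begin to separate them.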